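Hydroxy in place of nitro: from compound 2 to compound 4

The source may hold more compounds than are shown below. What is called first, only, known or untested is meant among the compounds shown, and "the series" means these compounds.

Measured in an ADME assay on MT4 cells (Homo sapiens) for cytotoxicity, read by MTT assay (a higher number here means that more compound is tolerated, a lower number that less compound is tolerated), so far:
compound 1 `O=C(CSc1nnnn1-c1cccc2ccccc12)N/N=C/c1ccc(F)cc1`: > 307000 nM, a limit of the assay
compound 2 `O=C(CSc1nnnn1-c1cccc2ccccc12)N/N=C/c1ccc([N+](=O)[O-])cc1`: >= 260000 nM, a limit of the assay
compound 3 `O=C(CSc1nnnn1-c1cccc2ccccc12)N/N=C/c1cccc(O)c1`: 169000 nM

Compound 2 stands at a limit in this assay: compound 2 gives >= 260000 nM, which is a limit of the assay and not a number (the limit of >= 260000 nM in this assay, at which 1 of the 3 values shown sits). Compound 1 also stands at a limit (the limit of > 307000 nM in this assay, at which 1 of the 3 values shown sits). Only compound 3 gives a number. Compound 4 `O=C(CSc1nnnn1-c1cccc2ccccc12)N/N=C/c1ccc(O)cc1` differs from compound 2 by hydroxy in place of nitro on an aromatic carbon. For the measured compounds named here, two measured steps bear on this change. There is an at least 1.5-fold lower number from compound 2 to compound 3 (0.18 log units; that floor lies within the scatter) and an at least 1.8-fold lower number from compound 1 to compound 3 (0.25 log units; that floor lies within the scatter), each running from a limit down to a number, each with a floor that lies within the scatter. The third step, a step that the two limits leave unreadable from compound 1 to compound 2, tells nothing about size. The step is therefore expected to be an at least 1.3-fold lower number from compound 2 to compound 4 (0.11 log units; that floor lies within the scatter), towards a lower number, and perhaps not beyond the scatter. Compound 4 is accordingly expected to give 200000 nM, within a range from 100000 nM to 400000 nM.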

Compound 4, half-maximal cytotoxic concentration: > 309000 nM
Compound 4: a limit, no number; the forecaster's own chance of this, stated with the estimate: 40%; middle value at least 1.5-fold (0.18 log units) from the limit.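

In this assay compound 4 gives > 309000 nM, which is a limit of the assay and not a number. A hydroxy group on this aromatic ring therefore does not by itself bring a measurable number, and the change from 3-hydroxyphenyl to 4-hydroxyphenyl gives an at least 1.8-fold higher number from compound 3 to compound 4 (0.26 log units; that floor lies within the scatter). The steps joining compound 4 to compound 1 and to compound 2 cannot be read, since both ends of each are limits.

The compounds shown leave open whether nitro, fluoro and hydroxy differ at all at this place, since compound 1, compound 2 and compound 4 all end at limits. They also leave open whether an amine or a carboxylic acid on the same aromatic carbon would give a number that could be compared with that of compound 3.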